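The source may hold more compounds than are shown below. What is called first, only, known or untested is meant among the compounds shown, and "the series" means these compounds.

Measured so far in a functional assay on MCF7 cells (Homo sapiens) for antiproliferative activity, read by MTT assay, with a stated time of 72 h; a higher number here means a weaker inhibitor, a lower number a stronger inhibitor:
- compound 1 `CC(Nc1ncnc2ccc(-c3cnn(C4CCNCC4)c3)cc12)c1c(Cl)ccc(F)c1Cl`: 2650 nM
- compound 2 `CC(Nc1nc(N)nc2ccc(-c3cnn(C4CCNCC4)c3)cc12)c1c(Cl)ccc(F)c1Cl`: 2230 nM

Compound 1 holds the highest of the two numbers, and its nearest neighbour is compound 2, with a 1.2-fold lower number from compound 1 to compound 2 (0.07 log units; within the scatter); the two cannot be told apart on this assay. That single step concerns an amino group on the shared core and leaves the group on the ring nitrogen untouched.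

Compound 3 `c1cnc2ccc(Nc3ncnc4ccc(-c5cnn(C6CCNCC6)c5)cc34)cc2c1` differs from compound 1 in exactly that untouched part: quinolin-6-yl in place of 1-(2,6-dichloro-3-fluorophenyl)ethyl on a nitrogen on an aromatic ring. Going by the values given here, no measured pair changes the group on that nitrogen, so the step from compound 1 to compound 2 gives no guide to the direction or size here, and the expectation rests on the change being a wholesale exchange of the group rather than a small edit.

Among the compounds with values here, for compound 3 the estimate in this assay is 4000 nM, within 700 nM to 25000 nM, which would mean an expected step of a 1.5-fold higher number from compound 1 to compound 3 (0.18 log units; within the scatter) from compound 1, with the range left wide because no measured step covers this position.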

Compound 3, half-maximal inhibitory concentration: 61900 nM
Compound 3: the middle estimate sits 15-fold (1.19 log units) below what was measured; the whole stated range lies below it.
By their numbers in this assay, from the lowest: compounds 2 and 1 (each within the scatter of the next); then compound 3.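

In this assay, the group on the nitrogen is where the series first shows a large change: quinolin-6-yl in place of 1-(2,6-dichloro-3-fluorophenyl)ethyl gives a 23-fold higher number from compound 1 to compound 3 (1.37 log units; beyond the scatter). An aromatic ring system on this nitrogen is therefore not enough to keep the number of compound 1, at least in the case of quinolin-6-yl. The exchange removes the chlorine and fluorine atoms and brings in a ring nitrogen all at once, and no measurement at hand bears on which of these differences accounts for the step.

Open, going by these compounds, is whether a 1-phenylethyl group without halogens, or a plain phenyl, on this nitrogen would stay close to compound 1 or fall towards compound 3. Also open, on these data alone, is whether an amino group on the shared core would change anything once quinolin-6-yl is in place.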